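The source may report more compounds than this note shows. Statements on the series, on what has been measured and on what is new or still open speak of the compounds shown alone.

Measured so far in a functional assay on NCI-H460 cells (Homo sapiens) for cytotoxicity, read by MTT assay, with a stated time of 72 h; a lower number here means a stronger inhibitor, a higher number a weaker inhibitor:
Compound 1 `CN(C)CCn1cnnc1-c1cc(Oc2ccc(NC(=O)N/N=C/c3cccc(Br)c3)cc2F)ccn1` gives 520 nM.
Compound 2 `CN(C)CCn1cnnc1-c1cc(Oc2ccc(NC(=O)N/N=C/c3ccc(Cl)cc3)cc2F)ccn1` gives 320 nM.
Compound 3 `Cc1cc(/C=N/NC(=O)Nc2ccc(Oc3ccnc(-c4nncn4CCN(C)C)c3)c(F)c2)cc(C)c1O` gives 2010 nM.

Compound 3 stands highest of the three, set apart by a 3.9-fold higher number from compound 1 to compound 3 (0.59 log units; beyond the scatter) and by a 6.3-fold higher number from compound 2 to compound 3 (0.80 log units; beyond the scatter). Compound 4 `CN(C)CCn1cnnc1-c1cc(Oc2ccc(NC(=O)N/N=C/c3ccc(F)cc3)cc2F)ccn1` is reached from it by 4-fluorophenyl in place of 4-hydroxy-3,5-dimethylphenyl on a carbon with a double bond to nitrogen. The step most directly bearing on this change is a 6.3-fold higher number from compound 2 to compound 3 (0.80 log units; beyond the scatter), which moved a 4-halophenyl to the 4-hydroxy-3,5-dimethylphenyl; its reverse is the nearest guide. The step of a 1.6-fold lower number from compound 1 to compound 2 (0.21 log units; within the scatter) shows that the two halophenyl compounds sit close together. Compound 4 is therefore expected to fall back toward compounds 1 and 2, with a 5.0-fold lower number from compound 3 to compound 4 (0.70 log units; beyond the scatter) as the estimated step. The estimate for compound 4 in this assay is 400 nM, expected to lie between 180 nM and 900 nM.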

Compound 4, half-maximal inhibitory concentration: 1980 nM
Compound 4: the middle estimate sits 5.0-fold (0.69 log units) below what was measured; measured number outside the range, above it.
By their numbers in this assay, from the lowest: compounds 2 and 1 (each within the scatter of the next); then compounds 4 and 3 (each within the scatter of the next).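

In this assay, the aryl group on the carbon with a double bond to nitrogen does not sort simply by carrying a halogen: fluoro in place of chloro brings a 6.2-fold higher number from compound 2 to compound 4 (0.79 log units; beyond the scatter), and 4-fluorophenyl in place of 3-bromophenyl brings a 3.8-fold higher number from compound 1 to compound 4 (0.58 log units; beyond the scatter). The 4-fluorophenyl and 4-hydroxy-3,5-dimethylphenyl groups cannot be told apart here, with a 1.0-fold lower number from compound 3 to compound 4 (0.01 log units; within the scatter), so the earlier gap to compound 3 holds for the chloro and bromo compounds but not for the fluoro compound. Nothing available explains this difference among the halogens. The compounds shown leave open how a methoxy, trifluoromethyl or amino group on this ring would compare.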